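The source may hold more compounds than are shown below. What is called first, only, known or untested is meant among the compounds shown, and "the series" means these compounds.

Compound 1 `CCc1cc(N2CC[C@@H](C)[C@@H](N(C)c3ncnc4[nH]ccc34)C2)n2ncnc2n1` gives, as a limit of the assay, > 100000 nM.
Compound 2 `Cc1cc(N2CC[C@@H](C)[C@@H](N(C)c3ncnc4[nH]ccc34)C2)n2nc(SCc3nc4ccccc4[nH]3)nc2n1` gives, as a limit of the assay, > 100000 nM.
Compound 3 `Cc1nc2nc(SCc3ccc(Cl)cc3)nn2c(N2CC[C@@H](C)[C@@H](N(C)c3ncnc4[nH]ccc34)C2)c1C` gives, as a limit of the assay, > 100000 nM.

These values come from a functional assay on HGC-27 cells (Homo sapiens) for inhibition, read by MTT assay, with a stated time of 72 h; a higher number here means a weaker inhibitor, a lower number a stronger inhibitor. Compound 2 thus stands at the limit rather than at a number, and the other two stand there as well, since (the limit of > 100000 nM in this assay, at which 3 of the 3 values shown sit). No two of these compounds differ in only one place, so no measured step exists among them. Compound 4 `Cc1cc(N2CC[C@@H](C)[C@@H](N(C)c3ncnc4[nH]ccc34)C2)n2nc(SCc3ccc(F)cc3)nc2n1` differs from compound 2 as follows: 4-fluorophenyl in place of 1H-benzimidazol-2-yl on a saturated chain carbon bound to a sulfur. With every value shown sitting at the limit, no step beyond the scatter is expected, and the step that the limit leaves unreadable from compound 2 to compound 4 is expected to be about none. Compound 4 is therefore estimated at 150000 nM, with a range from 30000 nM to 600000 nM, most likely reported again only as a limit.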

Compound 4, half-maximal inhibitory concentration: 26000 nM
Beside the measured number, compound 4's estimate is 5.8-fold (0.76 log units) above it; measured number below the stated range.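

Within this assay the change to 4-fluorophenyl in place of 1H-benzimidazol-2-yl on a saturated chain carbon bound to a sulfur gives an at least 3.8-fold lower number from compound 2 to compound 4 (0.58 log units; beyond the scatter) and is the only readable step here. It shows that the group at this place can bring a compound off the assay limit. The size of the step remains a lower bound, since compound 2 has only a limit and no number: the limit of > 100000 nM in this assay, at which 3 of the 4 values shown sit.

Going by these compounds, whether a plain phenyl or a pyridine ring at this place would give a lower number remains open. So does whether the fluorine itself contributes to the step.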